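The source may report more compounds than this note shows. Statements on the series, on what has been measured and on what is new or still open speak of the compounds shown alone.

Measured in a functional assay on DU-145 cells (Homo sapiens) for inhibition, read by trypan blue exclusion, with a stated time of 96 h; a lower number here means a stronger inhibitor of growth, a higher number a weaker inhibitor of growth:
- compound 1 `Cc1ccc(S/C(=C/c2cnc3ccccc3c2)C(=O)c2ccc(Cl)cc2)cc1`: > 100000 nM (a limit of the assay, not a number)
- compound 2 `CSc1ccc(/C=C(\C(=O)c2ccc(Cl)cc2)S(=O)(=O)Cc2ccc(C)cc2)cc1`: 10000 nM
- compound 3 `O=C(/C(=C\c1c[nH]c2ccc(Cl)cc12)SCc1ccc(F)cc1)c1ccc(Br)cc1`: 1000 nM

Only two of these three results are true numbers. Of those two, compound 2 holds the higher at 10000 nM, making it the weaker inhibitor of growth. Compound 3 follows at 1000 nM, a gap beyond the usual scatter. Compound 1 reports only a limit, > 100000 nM.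

The account now turns to compound 4 `Cc1ccc(CS(=O)(=O)/C(=C/c2cccc(Cl)c2Cl)C(=O)c2ccc(Cl)cc2)cc1`, which has not yet been measured in this assay. It differs from compound 2 in one place: 2,3-dichlorophenyl in place of 4-(methylsulfanyl)phenyl on a double-bonded chain carbon bound to a double-bonded chain carbon. The exchange puts 2,3-dichlorophenyl in place of 4-(methylsulfanyl)phenyl, and the heavy-atom count of the group stays the same. No measured pair among these compounds shows what such an exchange does, so the expectation starts from compound 2 at 10000 nM. The expected step of a 1.3-fold lower number from compound 2 to compound 4 (0.10 log units; within the scatter) is slight, toward stronger inhibition, and not beyond the scatter, although the uncertainty around it is wide. The estimated value for compound 4 is 8000 nM, with an expected range of 1500 nM to 40000 nM.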

Compound 4, concentration for 50% growth inhibition: 1000 nM
Estimate against measurement, compound 4: 8.0-fold (0.90 log units) above, outside the stated range (below it).
By their numbers in this assay, from the lowest: compounds 3 and 4 (each within the scatter of the next); then compound 2. At a limit, above all of these: compound 1.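

In this assay, placing 2,3-dichlorophenyl where 4-(methylsulfanyl)phenyl stood, on a double-bonded chain carbon bound to a double-bonded chain carbon, gives a 10-fold lower number from compound 2 to compound 4 (1.00 log units; beyond the scatter), the first step among these compounds that isolates a single place. It shows that the choice of aryl group at this place can move growth inhibition beyond the scatter, even though both groups hold a six-membered aromatic ring of carbon only and the heavy-atom count stays the same; what differs in the count is that the group leaving carries sulfur and a hydrogen-bond acceptor, while the group entering carries two chlorine atoms and no acceptor. Nothing measured among these compounds gives a cause for this step.

The compounds shown leave open whether both chlorine atoms are needed, and how a phenyl group bearing a single chlorine, a methoxy group or an amine would compare at this place. From the compounds shown here alone, the step also rests on one pair, so it remains open whether the same exchange would act alike on the differently substituted frameworks of compound 1 and compound 3.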